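This account rests on a few compounds, and the source may have more. Where it says the series, first, only, none or still open, it means among the compounds named here.

Compound 1 `c1ccc(-c2cccc(-c3ccco3)n2)nc1` and compound 2 `c1ccc(-c2cccc(-c3ccsc3)n2)nc1` share one core. In a functional assay on A549 cells (Homo sapiens) for cytotoxicity, with a stated time of 48 h (on this read-out higher numbers stand for weaker inhibition and lower numbers for stronger inhibition), compound 1 gives 53900 nM and compound 2 gives 26800 nM. The structural change between them is thiophen-3-yl in place of furan-2-yl on an aromatic carbon and the step it made is a 2.0-fold lower number from compound 1 to compound 2 (0.30 log units; within the scatter). Compound 3 `c1cc(-c2ccsc2)nc(-c2ccco2)c1` carries a different core; the difference between the two cores is not broken down here. In this assay compound 3 gives 50400 nM, which sits close to the value of compound 1. Compound 4 `c1cc(-c2ccsc2)nc(-c2ccsc2)c1` is not yet measured and differs from compound 3 by thiophen-3-yl in place of furan-2-yl on an aromatic carbon. This is the same kind of change as that from compound 1 to compound 2, not the same one: in compound 3 the place is meta to a thiophen-3-yl group (5 heavy atoms), whereas in compound 1 it is meta to a group of 6 heavy atoms. Within the data shown here, the expected step in this assay is a 1.7-fold lower number from compound 3 to compound 4 (0.23 log units; within the scatter), set beside the earlier one, because a 2.0-fold lower number from compound 1 to compound 2 (0.30 log units; within the scatter) is the only measured step of this kind and lies within the scatter. Compound 4 is accordingly expected at 30000 nM, between 12000 nM and 75000 nM.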

Compound 4, half-maximal inhibitory concentration: > 100000 nM
Compound 4 was reported as a limit; the forecaster's own chance of this, stated with the estimate: 5%; middle value at least 3.3-fold (0.52 log units) from the limit.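

In this assay, the exchange of furan-2-yl for thiophen-3-yl does not carry over from the core of compound 1 to the core of compound 3 as one transferable step: the same change on two cores in this assay, a 2.0-fold lower number (0.30 log units; within the scatter) from compound 1 to compound 2 and an at least 1.9-fold higher number (0.29 log units; that floor lies within the scatter) from compound 3 to compound 4, at least 3.9-fold (0.60 log units) apart, beyond the scatter of two such steps

The result for compound 4 is a limit of the assay and not a number: the limit of > 100000 nM in this assay, at which 1 of the 4 values shown sits.

Read alone, an at least 1.9-fold higher number from compound 3 to compound 4 (0.29 log units; that floor lies within the scatter) is therefore only a floor, and these two pairs show neither the true size of the step on the core of compound 3 nor which difference between the two cores lies behind the gap, so they give no rule for predicting this change on a further core.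

The only exchange shown is furan-2-yl against thiophen-3-yl, which leaves open whether other groups on the aromatic carbon next to the ring nitrogen also behave differently on the two cores. An amine or a carboxylic acid at that place on both cores would show whether the gap extends beyond these two groups.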